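From 3-nitrophenyl to 2-nitrophenyl on a shared core

The compounds below may be only part of what the source reports. "The series", "measured", "known", "first", "only" and "open" are said of these compounds alone.

- compound 1 `CC1=CC[C@H]2[C@H](CC[C@]2(C)O)C(C)(C)[C@@H]1CC[C@H]1[C@]2(C)CC[C@H](OC(=O)c3ccc(Cl)cc3)C(C)(C)O[C@H]2CC[C@@]1(C)O` gives 24100 nM
- compound 2 `CC1=CC[C@H]2[C@H](CC[C@]2(C)O)C(C)(C)[C@@H]1CC[C@H]1[C@]2(C)CC[C@H](OC(=O)c3ccc(Cl)c(Cl)c3)C(C)(C)O[C@H]2CC[C@@]1(C)O` gives 11900 nM
- compound 3 `CC1=CC[C@H]2[C@H](CC[C@]2(C)O)C(C)(C)[C@@H]1CC[C@H]1[C@]2(C)CC[C@H](OC(=O)c3cccc([N+](=O)[O-])c3)C(C)(C)O[C@H]2CC[C@@]1(C)O` gives 36000 nM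

In a functional assay on MCF7 cells (Homo sapiens) for antiproliferative activity, read by MTT assay, with a stated time of 72 h (a higher number here means a weaker inhibitor, a lower number a stronger inhibitor), compound 3 gives 36000 nM as its value. Two measured steps end there (a 1.5-fold higher number from compound 1 to compound 3 (0.17 log units; within the scatter)) and (a 3.0-fold higher number from compound 2 to compound 3 (0.48 log units; beyond the scatter)), and both exchange the whole group on a carbonyl carbon. Compound 4 `CC1=CC[C@H]2[C@H](CC[C@]2(C)O)C(C)(C)[C@@H]1CC[C@H]1[C@]2(C)CC[C@H](OC(=O)c3ccccc3[N+](=O)[O-])C(C)(C)O[C@H]2CC[C@@]1(C)O` has 2-nitrophenyl in place of 3-nitrophenyl on that carbonyl carbon (2-nitrophenyl in place of 3-nitrophenyl on a carbonyl carbon). Going by the values given here, no measured step moves the nitro group itself. The third step, adding a chloro, was also small (a 2.0-fold lower number from compound 1 to compound 2 (0.31 log units; beyond the scatter)). Even the largest step is only modest (a 3.0-fold higher number from compound 2 to compound 3 (0.48 log units; beyond the scatter)), so no change beyond the scatter is expected. The estimated step is small (a 1.2-fold lower number from compound 3 to compound 4 (0.08 log units; within the scatter)). Compound 4 is estimated at 30000 nM (expected range 14000 nM to 62000 nM).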

Compound 4, half-maximal inhibitory concentration: 5200 nM
For compound 4 the middle estimate is 5.8-fold (0.76 log units) above the measured one, outside the stated range (below it).
By their numbers in this assay, from the lowest: compound 4; then compound 2; then compounds 1 and 3 (each within the scatter of the next).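

Moving the nitro group, with the atoms of the group unchanged, gives a 6.9-fold lower number from compound 3 to compound 4 (0.84 log units; beyond the scatter), the largest step among these compounds, so activity here depends on where the nitro group sits on the ring and not only on which atoms the group contains. The 2-nitrophenyl group also gives lower numbers than the 4-chlorophenyl and 3,4-dichlorophenyl groups, with a 4.6-fold lower number from compound 1 to compound 4 (0.67 log units; beyond the scatter) and a 2.3-fold lower number from compound 2 to compound 4 (0.36 log units; beyond the scatter). Nothing available explains why this isomer behaves differently. From the compounds shown here alone, whether 4-nitrophenyl would follow either isomer remains open, as does whether 2-aminophenyl or 2-methoxyphenyl on that carbonyl carbon would keep the low number.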